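This account rests on a few compounds, and the source may have more. Where it says the series, first, only, none or still open, it means among the compounds named here.

Measured compounds:
compound 1 `CCCCCCCCCCc1ccc(-c2noc(C3CNC3)n2)cc1` — 65%
compound 2 `CCCCCCCCCCc1ccc(-c2noc(CN)n2)cc1` — 62%

In an assay on HeLa cells for inhibition of sphingosine-1-phosphate transporter SPNS2 (Mus musculus), read by LC-MS, tested at 2 uM (a lower number here means less inhibition, a higher number more inhibition at the concentration tested (going by the name of the read-out)), compound 1 gives 65% and compound 2 gives 62%. The one step between them, a number 3 percentage points lower from compound 1 to compound 2 (within the scatter), lies within the scatter, so compound 2 and compound 1 stand together on the numbers shown, with nothing to separate them.

Compound 3 `CCCCCCCCCCc1ccc(-c2noc(CCCN)n2)cc1` is not yet measured in this assay. It differs from compound 2 by 2-aminoethyl in place of amino on a saturated chain carbon bound to an aromatic carbon. Among the measured compounds shown here, the only measured step that touches this part of the shared core is the exchange of azetidin-3-yl for aminomethyl, and that step was flat. For the measured compounds named here, nothing measured so far tells how a longer chain behaves, so the expectation rests on that flat step alone: a step of a number 2 percentage points lower from compound 2 to compound 3 (within the scatter) is expected, none beyond the scatter. For compound 3 the estimate in this assay is 60%, between 42% and 78%.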

Compound 3, a percentage reported as inhibition, at one concentration (the size of the read-out at that concentration, not a potency): 67%
Compound 3: middle estimate off by 7 percentage points, on the low side, and the stated range covers the measured number.
By their numbers in this assay, from the lowest: compounds 2, 1 and 3 (each within the scatter of the next).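

With 2-aminoethyl in place of amino on a saturated chain carbon bound to an aromatic carbon, the step in this assay is a number 5 percentage points higher from compound 2 to compound 3 (within the scatter), so a chain extended this far does not separate from aminomethyl. Set against the ring-bearing compound, the step is a number 2 percentage points higher from compound 1 to compound 3 (within the scatter), which means that azetidin-3-yl, aminomethyl and 3-aminopropyl cannot be told apart at this position in this assay. No supporting evidence bears on this result.

From the compounds shown here alone, what a plain propyl chain, a carboxylic acid or a longer amine such as 5-aminopentyl would give at this place stays open. Also open, going by these compounds, is whether the three compounds differ in potency, as a reading at one concentration cannot show that.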